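Changing the acid-bearing arm on a shared core

This account rests on a few compounds, and the source may have more. Where it says the series, first, only, none or still open, it means among the compounds named here.

Measured compounds:
compound 1, `CC(C)c1onc(-c2c(Cl)cccc2Cl)c1COc1ccc(NC(=O)c2ccc(C(=O)O)cc2)c(C(F)(F)F)n1`, 48%
compound 2, `CC(C)c1onc(-c2c(Cl)cccc2Cl)c1COc1ccc(N(C)Cc2cccc(C(=O)O)c2)c(C(F)(F)F)n1`, 58%
compound 3, `CN(Cc1cccc(C(=O)O)c1)c1ccc(OCc2c(-c3c(Cl)cccc3Cl)noc2C2CC2)nc1C(F)(F)F`, 43%

Of the compounds shown here, three have been measured in a functional assay on HEK293 cells for agonist activity at Bile acid receptor (Homo sapiens), read by a luciferase reporter; a lower number here means a smaller maximal response, a higher number a larger maximal response. Compound 3 gives the lowest of the three numbers in this assay; its gap to compound 1 lies within the scatter, while compound 2 sits above it, with a number 15 percentage points lower from compound 2 to compound 3 (beyond the scatter).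

Compound 4, `O=C(O)c1ccccc1OCc1ccc(OCc2c(-c3c(Cl)cccc3Cl)noc2C2CC2)nc1C(F)(F)F`, is not yet measured. It differs from compound 3 at one place:

(2-carboxyphenoxy)methyl in place of (3-carboxybenzyl)(methyl)amino on an aromatic carbon

Among the measured compounds shown here, the only earlier step at this same place is the one from compound 1 to compound 2, where the acid-bearing arm was also exchanged for another and the result was a number 10 percentage points higher from compound 1 to compound 2 (within the scatter). The step from compound 2 to compound 3 concerns a different place and does not bear on this change. For the measured compounds named here, since the one exchange at this position stayed within the scatter, the expectation for compound 4 in this assay is a step of about a number 2 percentage points higher from compound 3 to compound 4 (within the scatter), that is, no clear change in either direction. Compound 4 is therefore estimated at 45%, within a range from 30% to 60%.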

Compound 4, largest response reached (reported as efficacy), in percent of the reference or control that the assay uses: 33%
Compound 4: the middle estimate sits 12 percentage points above what was measured; the measured number falls inside the stated range.
By their numbers in this assay, from the lowest: compounds 4, 3, 1 and 2 (each within the scatter of the next, the first and the last beyond it).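

Swapping the nitrogen-linked (3-carboxybenzyl)(methyl)amino arm for the nitrogen-free (2-carboxyphenoxy)methyl arm gives, in this assay, a number 10 percentage points lower from compound 3 to compound 4 (within the scatter), so no clear change can be claimed even though the atoms joining the arm to the shared core and the place of the acid on the benzene ring both differ. This is the second exchange of the acid-bearing arm to stay within the scatter, and it was made on the cyclopropyl compound, whereas the earlier exchange was made on the isopropyl compound; across these two pairs, then, the maximal response shows no clear dependence on which of these arms is attached. No available data explain the size or direction of this step.

Each arm shown ends in a carboxylic acid on a benzene ring, so it remains open how the response would behave with a primary amide or a hydroxyl group in place of that acid. Also open, on these data alone, is the effect of a longer chain between the core and the benzene ring, or of the (2-carboxyphenoxy)methyl arm paired with the isopropyl group.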